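Hydroxymethyl to methylcarbamoyl: microsomal clearance notes

The compounds below may be only part of what the source reports. "The series", "measured", "known", "first", "only" and "open" are said of these compounds alone.

Measured in an ADME assay on microsomes from liver (Homo sapiens) for metabolic stability, read by LC-MS, using NADPH, with stated times of 5 min and 30 min, tested at 1 uM; a higher number here means faster removal of the compound, a lower number slower removal:
- compound 1, `Cc1nc(CO)ccc1-c1cnc(NCc2c(F)ccc3c2CCO3)c2cn[nH]c(=O)c12`, gives 11 mL.min-1.g-1
- compound 2, `CC1(C)CC(=O)N(c2cnc(NCc3c(F)ccc4c3CCO4)n3cnnc23)C1`, gives 16 mL.min-1.g-1

Compound 1 has the lowest of the two numbers, but its gap to compound 2 is within the scatter, so the two are not separable. Compound 3, `CNC(=O)c1ccc(-c2cnc(NCc3c(F)ccc4c3CCO4)c3cn[nH]c(=O)c23)c(C)n1`, is not yet measured. It differs from compound 1 by methylcarbamoyl in place of hydroxymethyl on an aromatic carbon. Going by the values given here, no step between the measured compounds matches this change, so no size can be read from the series. The step from hydroxymethyl to methylcarbamoyl is expected to stay within the scatter, a 1.1-fold lower number from compound 1 to compound 3 (0.04 log units; within the scatter). Compound 3 is estimated at 10 mL.min-1.g-1, range 5 mL.min-1.g-1 to 22 mL.min-1.g-1.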

Compound 3, intrinsic clearance in microsomes: 23 mL.min-1.g-1
Compound 3: middle estimate off by 2.3-fold (0.36 log units), on the low side, outside the stated range (above it).
By their numbers in this assay, from the lowest: compounds 1, 2 and 3 (each within the scatter of the next, the first and the last beyond it).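

On an aromatic carbon next to the ring nitrogen, this position is not indifferent to its substituent in this assay: methylcarbamoyl in place of hydroxymethyl gives a 2.1-fold higher number from compound 1 to compound 3 (0.32 log units; beyond the scatter), a modest step and the first one readable in the series. Hydroxymethyl therefore holds the lower number of this pair. Nothing measured bears on the reason for the step.

From the compounds shown here alone, whether the step follows the amide itself or its methyl stays open; a primary carboxamide, a carboxylic acid or an aminomethyl group at this position would separate the two. Going by these compounds, whether the same step holds on the core of compound 2 also stays open.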